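The source may hold more compounds than are shown below. What is called first, only, known or untested is meant among the compounds shown, and "the series" means these compounds.

Three compounds have been measured in an assay on cells for inhibition of sodium/hydrogen exchanger (Oryctolagus cuniculus); a higher number here means a weaker inhibitor, a lower number a stronger inhibitor:

Compound 1, `Cc1cc2c(cc1C(=O)N=C(N)N)S(=O)(=O)CCC2C`, gives 45 nM.
Compound 2, `Cc1cc2c(cc1C(=O)N=C(N)N)S(=O)(=O)CCC2`, gives 95 nM.
Compound 3, `Cc1cc2c(cc1C(=O)N=C(N)N)S(=O)(=O)C(C)C2N`, gives 56 nM.

Compound 1 and compound 2 share a core and differ in one place: hydrogen in place of methyl on a saturated ring carbon. That change gave a 2.1-fold higher number from compound 1 to compound 2 (0.32 log units; beyond the scatter). Compound 3 is built on a different core; the difference between the core of compound 1 and the core of compound 3 is not broken down here. Its value lies within the scatter of both compound 1 and compound 2, so no order among the three can be read from these numbers.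

Compound 4, `Cc1cc2c(cc1C(=O)N=C(N)N)S(=O)(=O)CC2N`, has not yet been measured in this assay. It differs from compound 3 by hydrogen in place of methyl on a saturated ring carbon. Going by the values given here, this is the same kind of change as the one from compound 1 to compound 2, but not the same: there the methyl sat on a saturated ring carbon of a six-membered non-aromatic ring with 1 sulfur, three ring bonds from the ring sulfur; here it sits on a saturated ring carbon of a five-membered non-aromatic ring with 1 sulfur, next to the ring sulfur and next to the ring atom that bears an amino group. Among the compounds with values here, only one measured instance of this kind of change exists, so the expectation rests on that single step. Compound 4 is expected to come out a little weaker than compound 3, by an estimated step of a 2.0-fold higher number from compound 3 to compound 4 (0.29 log units; within the scatter), because the same kind of change gave a 2.1-fold higher number from compound 1 to compound 2 (0.32 log units; beyond the scatter). The estimate for compound 4 in this assay is 110 nM, with an expected range from 50 nM to 250 nM.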

Compound 4, half-maximal inhibitory concentration: 116 nM
For compound 4 the middle estimate is 1.1-fold (0.02 log units) below the measured one; low and high end bracket the measured number.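

In this assay hydrogen in place of methyl on a saturated ring carbon gave a 2.1-fold higher number from compound 3 to compound 4 (0.32 log units; beyond the scatter) and so matched, on a second core, the size of the earlier step: the same change on two cores in this assay, a 2.1-fold higher number (0.32 log units; beyond the scatter) from compound 1 to compound 2 and a 2.1-fold higher number (0.32 log units; beyond the scatter) from compound 3 to compound 4, 1.0-fold (0.01 log units) apart, within the scatter of two such steps. The change therefore carried over between these two cores without a detectable difference, even though the carbon on the newer core sits in a five-membered non-aromatic ring with 1 sulfur, next to the ring sulfur and next to the ring atom that bears an amino group. This rests on just one pair of compounds per core, so it does not show that the step would keep its size on any further core, and it gives no reason why the two steps agree.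

The compounds shown leave open whether ethyl or a longer chain on that saturated ring carbon would extend the trend seen from hydrogen to methyl, or break it. They also leave open how a hydroxyl group or a dimethylamino group in place of the amino group would behave on the core of compound 4, and whether the methyl step would stay the same size there.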